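The source may report more compounds than this note shows. Statements on the series, on what has been measured and on what is new or still open speak of the compounds shown alone.

Among the measured compounds shown here, compound 3 `CC(C)[C@H](NC(=O)COc1cccc2ccccc12)C(=O)N[C@@H](CC(=O)O)C(=O)COc1c(F)ccc(F)c1F` gives the only numerical reading in a functional assay on Jurkat cells (Homo sapiens) (a higher number here means a weaker inhibitor, a lower number a stronger inhibitor), at 1200 nM. Compound 1 `CC(C)[C@H](NC(=O)COc1cccc2ccccc12)C(=O)N[C@@H](CC(=O)O)C(=O)COc1cccc(C(F)(F)F)c1` returns a limit in this assay, > 100000 nM. Compound 2 `CC(C)[C@H](NC(=O)COc1cccc2ccccc12)C(=O)N[C@@H](CC(=O)O)C(=O)COc1cc(F)ccc1F` likewise returns a limit, > 100000 nM. The steps of an at least 83-fold lower number from compound 1 to compound 3 (1.92 log units; beyond the scatter) and an at least 83-fold lower number from compound 2 to compound 3 (1.92 log units; beyond the scatter) are thus read against (the limit of > 100000 nM in this assay, at which 2 of the 3 values shown sit), while the step that the two limits leave unreadable from compound 1 to compound 2 cannot be sized. Compound 4 `CC(C)[C@H](NC(=O)COc1cccc2ccccc12)C(=O)N[C@@H](CC(=O)O)C(=O)COc1ccc([N+](=O)[O-])cc1F` alters the same phenyl: 2-fluoro-4-nitrophenyl in place of 2,3,6-trifluorophenyl on an oxygen on a saturated carbon. The closest comparison is the fluoro step from compound 2, which was large, so this assay appears highly sensitive to substitution on that ring. For compound 4 a large rise in this assay is expected, a 25-fold higher number from compound 3 to compound 4 (1.40 log units; beyond the scatter), with a fair chance of another limit. Compound 4 is estimated at 30000 nM, between 3000 nM and 150000 nM.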

Compound 4, half-maximal inhibitory concentration: 30300 nM
For compound 4 the middle estimate is 1.0-fold (0.00 log units) below the measured one, and the stated range covers the measured number.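

In this assay, the 2-fluoro-4-nitrophenyl group on this oxygen gives a measurable number, though the 2,3,6-trifluorophenyl group remains clearly better, with a 25-fold higher number from compound 3 to compound 4 (1.40 log units; beyond the scatter). A measurable number at this position is therefore not confined to the 2,3,6-trifluorophenyl group, as 2-fluoro-4-nitrophenyl also outperforms the two other rings, with an at least 3.3-fold lower number from compound 2 to compound 4 (0.51 log units; beyond the scatter) and an at least 3.3-fold lower number from compound 1 to compound 4 (0.51 log units; beyond the scatter). Going by these compounds, the true size of these last two steps stays unknown, as both are read against a limit: the limit of > 100000 nM in this assay, at which 2 of the 4 values shown sit.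

On these data alone, it remains open how much of the reading depends on the fluoro and how much on the nitro group. A nitrile or an amine in place of the nitro group would test that ring further.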